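From 2-phenylethynyl to 2,4-difluorophenyl on a shared core

This account rests on a few compounds, and the source may have more. Where it says the series, first, only, none or still open, it means among the compounds named here.

In a functional assay on LN-229 cells (Homo sapiens) for antiproliferative activity, with a stated time of 72 h (a higher number here means a weaker inhibitor, a lower number a stronger inhibitor), compound 1 `Nc1ncnn2c([C@@H]3O[C@H](CO)[C@@H](O)[C@H]3O)cc(C#Cc3ccc(F)cc3)c12` gives > 100000 nM, which is a limit of the assay and not a number. Going by the values given here, compound 2 `Nc1ncnn2c([C@@H]3O[C@H](CO)[C@@H](O)[C@H]3O)cc(C#Cc3ccccc3)c12` gives 88000 nM, the only actual number so far. Among the compounds with values here, the sole measured step is an at least 1.1-fold lower number from compound 1 to compound 2 (0.05 log units; that floor lies within the scatter), for hydrogen in place of fluoro on an aromatic carbon. That step leaves the 2-phenylethynyl group untouched, so it offers little guidance for the next change. Compound 3 `Nc1ncnn2c([C@@H]3O[C@H](CO)[C@@H](O)[C@H]3O)cc(-c3ccc(F)cc3F)c12` differs from compound 2 as follows: 2,4-difluorophenyl in place of 2-phenylethynyl on an aromatic carbon. Within the data shown here, no measured step replaces this group, so the size of the effect remains open. With compound 2 at 88000 nM, a modest move towards a lower number in this assay is expected, and the estimated step is a 2.2-fold lower number from compound 2 to compound 3 (0.34 log units; beyond the scatter). For compound 3 the expected value is 40000 nM, with an estimated range of 5000 nM to 100000 nM.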

Compound 3, half-maximal inhibitory concentration: 43500 nM
For compound 3 the middle estimate is 1.1-fold (0.04 log units) below the measured one, and the stated range covers the measured number.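

Going by these compounds alone, this is the first measured change to the group on the five-membered aromatic ring itself, not just to a substituent on its outer phenyl ring. In this assay, removing the triple bond and placing a 2,4-difluorophenyl group on that aromatic carbon gives a 2.0-fold lower number from compound 2 to compound 3 (0.31 log units; beyond the scatter), so the number falls rather than rises when the 2-phenylethynyl group leaves. The comparison with the fluorinated alkyne gives an at least 2.2-fold lower number from compound 1 to compound 3 (0.36 log units; beyond the scatter). That size is only a floor, because compound 1 stands at a limit of the assay and not at a number: the limit of > 100000 nM in this assay, at which 1 of the 3 values shown sits.

This single change removes the triple bond and adds two fluorines together, so the contribution of each remains unresolved. As far as these compounds go, whether a plain phenyl, a pyridine ring or an aminophenyl group in this place would lower the number further also stays open.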